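Replacing 3-methylphenyl with tert-butyl in compound 1

The compounds below may be only part of what the source reports. "The series", "measured", "known", "first", "only" and "open" are said of these compounds alone.

In an ADME assay on liver for metabolic stability, with Liver microsome (Homo sapiens) as the target, read by LC-MS, using microsomes (on this read-out higher numbers stand for fast clearance and lower numbers for slow clearance), compound 1 `Cc1cccc([C@@H](O)C(=O)N2N=CC[C@H]2C(=O)NCc2cc(Cl)ccc2-n2cnnn2)c1` gives < 12 mL.min-1.g-1, which is a limit of the assay and not a number. Compound 1 thus stands at the limit of < 12 mL.min-1.g-1 in this assay, at which 1 of the 3 values shown sits. Compound 4 `CC(C)(C)[C@@H](O)C(=O)N1N=CC[C@H]1C(=O)NCc1cc(Cl)ccc1-n1cnnn1` differs from it by tert-butyl in place of 3-methylphenyl on a saturated chain carbon bound to a carbonyl carbon and an oxygen on a saturated carbon, with tert-butyl in place of 3-methylphenyl. Within the data shown here, no measured step makes this exact swap. The nearest evidence comes from another core, where compound 2 `CC(C)(C)OC[C@@H](O)C(=O)N1[C@H](C(=O)NCc2cc(Cl)ccc2-n2cnnn2)C[C@@H]2C[C@@H]21` gives 21 mL.min-1.g-1 and compound 3 `O=C(NCc1cc(Cl)ccc1-n1cnnn1)[C@@H]1C[C@@H]2C[C@@H]2N1C(=O)[C@H](O)C1CCCCC1` gives 150 mL.min-1.g-1. That change at the same place, cyclohexyl in place of (tert-butoxy)methyl, is a 7.1-fold higher number from compound 2 to compound 3 (0.85 log units; beyond the scatter), so this carbon can matter. Yet compound 2, with no ring there, stays at 21 mL.min-1.g-1, so only a small rise is expected. The expected step is an at least 1.1-fold higher number from compound 1 to compound 4 (0.06 log units; that floor lies within the scatter). For compound 4 the estimate is 14 mL.min-1.g-1, with an expected range from 6 mL.min-1.g-1 to 35 mL.min-1.g-1.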

Compound 4, intrinsic clearance in microsomes: < 12 mL.min-1.g-1
Compound 4 gave a limit, no number (the forecaster's own chance of this, stated with the estimate: 45%); middle value at least 1.1-fold (0.06 log units) away from the limit.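

In this assay, among these compounds, compound 1 and compound 4 each give a limit and not a number, so no step between them can be read: the limit of < 12 mL.min-1.g-1 in this assay, at which 2 of the 4 values shown sit. From the compounds shown here alone, whether tert-butyl in place of 3-methylphenyl changes the clearance at all stays open.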